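A few compounds are considered here, and "the series" means these few. Any claim that something is new, unique, unknown or untested is made for them only; others in the source may bear on it.

Compound 1 `Cc1n[nH]c2ccc(-c3nc4cnc(N5CCN(C)CC5)cn4c3Nc3ccc(Cl)cc3)cc12` and compound 2 `COc1ccc(Nc2c(-c3ccc4[nH]nc(C)c4c3)nc3cnc(N4CCN(C)CC4)cn23)cc1` share the core of compound 3 `Cc1n[nH]c2ccc(-c3nc4cnc(N5CCN(C)CC5)cn4c3Nc3ccc(Cl)cc3F)cc12` and compound 4 `Cc1n[nH]c2ccc(-c3nc4cnc(N5CCN(C)CC5)cn4c3Nc3cc(Cl)ccc3Cl)cc12`. In a functional assay on CWR22R cells (Homo sapiens) for inhibition, with a stated time of 120 h, tested at 10 uM (on this read-out lower numbers stand for less inhibition and higher numbers for more inhibition at the one concentration tested (going by the name of the read-out)), compound 1 gives 8.11%; in this assay compound 2 gives 0%. Within the data shown here, the one measured step, a number 8.1 percentage points lower from compound 1 to compound 2 (within the scatter), is a change of one substituent on the aromatic ring on the nitrogen and leaves the read-out flat. In this assay compound 3 gives "not determined" (no result reported), so it stands nowhere on the numbers. The step to compound 4 is 2,5-dichlorophenyl in place of 4-chloro-2-fluorophenyl on a nitrogen on an aromatic ring. Among the measured compounds shown here, no measured step touches this pair of rings, so the only guide is that both measured compounds sit near the bottom of the scale in this assay. Compound 4 is therefore expected to give 5%, estimated between 0% and 22%.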

Compound 4, a percentage reported as inhibition, at one concentration (the size of the read-out at that concentration, not a potency): 3.8%
For compound 4 the middle estimate is 1.2 percentage points above the measured one, and the stated range covers the measured number.
By their numbers in this assay, from the lowest: compounds 2, 4 and 1 (each within the scatter of the next).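

In this assay, 2,5-dichlorophenyl in place of 4-chlorophenyl gives a number 4.3 percentage points lower from compound 1 to compound 4 (within the scatter), and in place of 4-methoxyphenyl it gives a number 3.8 percentage points higher from compound 2 to compound 4 (within the scatter). The flat read-out at this nitrogen therefore extends from rings with one substituent to a ring with two, across compounds 1, 2 and 4. No supporting evidence bears on why the read-out stays flat here.

As far as these compounds go, whether an amine or a carboxylic acid on this phenyl ring, or cyclohexyl in its place, would move the number stays open. The fluorine of compound 3 also remains unread, as that compound has no reported result.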